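A few compounds are considered here, and "the series" means these few. Any claim that something is new, unique, unknown or untested is made for them only; others in the source may bear on it.

In a functional assay on CHO cells for positive allosteric modulation of muscarinic acetylcholine receptor M5 (Homo sapiens), read by FLIPR and calcium flux, with a stated time of 1 h (on this read-out higher numbers stand for an effect only at larger amounts of compound and lower numbers for an effect already at smaller amounts), compound 3 `O=C1C(=O)N(Cc2ccc(-c3ccccc3)nc2)c2ccc(OC(F)(F)F)cc21` gives 3800 nM; it stands as the highest of the two numbers shown, with compound 2 `O=C1C(=O)N(Cc2ccc(Cl)nc2)c2ccc(OC(F)(F)F)cc21` nearest at 2400 nM. The step of a 1.6-fold higher number from compound 2 to compound 3 (0.20 log units; within the scatter) is small. Compound 1 `O=C1C(=O)N(Cc2ccc(-c3ccncc3)cn2)c2ccc(OC(F)(F)F)cc21` reaches only a limit of this assay, > 30000 nM, which is the limit of > 30000 nM in this assay, at which 1 of the 3 values shown sits. Compound 4 `O=C1C(=O)N(Cc2ccc(-c3ccncc3)nc2)c2ccc(OC(F)(F)F)cc21` differs from compound 3 by pyridin-4-yl in place of phenyl on an aromatic carbon. Among the compounds with values here, no measured step swaps phenyl for pyridin-4-yl on this ring, so the only guide is compound 1, where a pyridin-4-yl group on a related core gave a limit rather than a number. Compound 4 is therefore expected to show a rise in this assay, a step of about a 3.2-fold higher number from compound 3 to compound 4 (0.50 log units; beyond the scatter), and its value is estimated at 12000 nM, somewhere between 4000 nM and 40000 nM.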

Compound 4, half-maximal effective concentration: 4400 nM
For compound 4 the middle estimate is 2.7-fold (0.44 log units) above the measured one; low and high end bracket the measured number.
By their numbers in this assay, from the lowest: compounds 2, 3 and 4 (each within the scatter of the next). At a limit, above all of these: compound 1.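

At this place next to the ring nitrogen, the swap from phenyl to pyridin-4-yl gives a 1.2-fold higher number from compound 3 to compound 4 (0.06 log units; within the scatter) in this assay, so adding a hydrogen-bond acceptor to this ring leaves no readable difference. Chloro and pyridin-4-yl also cannot be told apart here, with a 1.8-fold higher number from compound 2 to compound 4 (0.26 log units; within the scatter). Nothing measured here explains this result.

Still open, on these data alone, is whether an amine or a carboxylic acid at this place would give a step beyond the scatter. Also open, as far as these compounds go, is how a morpholine ring or a longer alkyl chain would compare.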